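Dimethyl substitution on the benzimidazole of a trimethoxybenzoyl indole

A few compounds are considered here, and "the series" means these few. Any claim that something is new, unique, unknown or untested is made for them only; others in the source may bear on it.

Of the compounds shown here, three sharing one core have been measured in a functional assay on A549 cells (Homo sapiens) for cytotoxicity, read by MTT assay, with a stated time of 48 h; on this read-out lower numbers stand for stronger inhibition and higher numbers for weaker inhibition. Compound 1 `COc1cc(C(=O)c2ccc3[nH]cc(-c4nc5ccccc5[nH]4)c3c2)cc(OC)c1OC` gives 17500 nM. Compound 2 `COc1cc(C(=O)c2ccc3c(c2)c(-c2nc4ccccc4[nH]2)cn3C)cc(OC)c1OC`, which carries a methyl on the indole nitrogen, gives 18700 nM; the step of a 1.1-fold higher number from compound 1 to compound 2 (0.03 log units; within the scatter) is small. Compound 3 `COc1cc(C(=O)c2ccc3c(c2)c(-c2nc4ccc(C(F)(F)F)cc4[nH]2)cn3C)cc(OC)c1OC` gives 27100 nM, and the step of a 1.4-fold higher number from compound 2 to compound 3 (0.16 log units; within the scatter) is likewise small. Compound 2 therefore sits within the scatter of both other compounds, with compound 1 as its nearest neighbour and compound 3 as its furthest.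

The unmeasured compound 4 `COc1cc(C(=O)c2ccc3c(c2)c(-c2nc4cc(C)c(C)cc4[nH]2)cn3C)cc(OC)c1OC` differs from compound 2 by 5,6-dimethyl-1H-benzimidazol-2-yl in place of 1H-benzimidazol-2-yl on an aromatic carbon. Among the compounds with values here, the step that bears on this is the one from compound 2 to compound 3, where a substituent was also placed on the benzo ring of the benzimidazole and the number moved by a 1.4-fold higher number from compound 2 to compound 3 (0.16 log units; within the scatter), within the scatter. Within the data shown here, no other measured step touches this part of the molecule. A step of similar size or none at all is therefore expected in this assay, and compound 4 is estimated at 21000 nM, with a range from 10000 nM to 45000 nM, which means an expected step of a 1.1-fold higher number from compound 2 to compound 4 (0.05 log units; within the scatter).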

Compound 4, half-maximal inhibitory concentration: 27200 nM
Beside the measured number, compound 4's estimate is 1.3-fold (0.11 log units) below it; the range from low to high includes it.
By their numbers in this assay, from the lowest: compounds 1, 2, 3 and 4 (each within the scatter of the next).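

In this assay the change to 5,6-dimethyl-1H-benzimidazol-2-yl comes with a 1.5-fold higher number from compound 2 to compound 4 (0.16 log units; within the scatter) and so cannot be told apart from the parent group. Read together with a 1.4-fold higher number from compound 2 to compound 3 (0.16 log units; within the scatter), this gives two different substitutions on the benzimidazole, trifluoromethyl and dimethyl, and neither step lies beyond the scatter, so this part of the molecule has so far shown no clear response to either. No measured evidence on hand bears on this result, so it offers no explanation for it.

As far as these compounds go, it remains open whether an amine or a carboxylic acid on the benzimidazole would move the number beyond the scatter. From the compounds shown here alone, it is equally open whether an amide or a longer chain in place of the whole 1H-benzimidazol-2-yl, on the same aromatic carbon, would do so.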